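A few compounds are considered here, and "the series" means these few. Any claim that something is new, unique, unknown or untested is made for them only; others in the source may bear on it.

Of the compounds shown here, two built on one shared core have been measured in an assay for inhibition of 3-oxo-5-alpha-steroid 4-dehydrogenase 1 (Homo sapiens), tested at 10 uM; on this read-out higher numbers stand for more inhibition at the one concentration tested (going by the name of the read-out) and lower numbers for less inhibition. Compound 1 `O=C(O)c1ccc(C=C2CCN(C(=O)C(C3CCCCC3)C3CCCCC3)CC2)cc1` gives 46% in this assay. Compound 2 `O=C(O)c1ccc(C=C2CCN(C(=O)C(c3ccccc3)c3ccccc3)CC2)c(F)c1` gives 2% in this assay, the lowest of the two numbers; its nearest neighbour, compound 1, stands higher by a gap beyond the usual scatter, and since these two differ in more than one place, no single change can be read out of that gap. Compound 3 `O=C(O)c1cccc(C=C2CCN(C(=O)C(c3ccccc3)c3ccccc3)CC2)c1` has not yet been measured. It differs from compound 2 in one place: 3-carboxyphenyl in place of 4-carboxy-2-fluorophenyl on a double-bonded chain carbon bound to a double-bonded ring carbon. Within the data shown here, no measured pair isolates this change, so its effect is open. Because compound 2 sits near the bottom of the read-out with 2%, the step is expected to be upward if anything, and modest: a number 10 percentage points higher from compound 2 to compound 3 (within the scatter). Compound 3 is therefore estimated at 12%, with a range from 0% to 40%.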

Compound 3, a percentage reported as inhibition, at one concentration (the size of the read-out at that concentration, not a potency): 6%
Compound 3: middle estimate off by 6 percentage points, on the high side; the measured number falls inside the stated range.
By their numbers in this assay, from the lowest: compounds 2 and 3 (each within the scatter of the next); then compound 1.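

In this assay, among these compounds, compound 2 and compound 3 form the first pair that differs only at the aryl group on a double-bonded chain carbon bound to a double-bonded ring carbon, and the step is a number 4 percentage points higher from compound 2 to compound 3 (within the scatter). Exchanging 4-carboxy-2-fluorophenyl for 3-carboxyphenyl removes the fluorine and changes the numbered place of the carboxy group together, yet the two compounds cannot be told apart on this read-out. Nothing shown gives a reason for this result.

Both changes lie within one step, so the pair cannot show what either would do alone, and both compounds sit near the bottom of the read-out. Also open, on these data alone, is how this position behaves on the dicyclohexyl-bearing core of compound 1, which gives 46%, or with a tetrazole or methyl ester in place of the carboxylic acid.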